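The compounds below may be only part of what the source reports. "The series", "measured", "known", "first", "only" and "open" are said of these compounds alone.

Values so far in a functional assay, read by spectrophotometry, with a stated time of 1 h; on this read-out lower numbers stand for stronger inhibition and higher numbers for weaker inhibition:
- compound 1 `O=c1cc(/C=N\O)c2c(OCc3ccccc3)cc(OCc3ccccc3)cc2o1`: "not active" (no number reported)
- compound 2 `Nc1ccccc1/N=C\c1cc(=O)oc2cc(OCc3ccccc3)ccc12`: 34600 nM
- compound 3 `O=c1cc(/C=N\Nc2ccc([N+](=O)[O-])cc2)c2ccc(OCc3ccccc3)cc2o1`: > 2000000 nM

Compound 3 gives > 2000000 nM, which is a limit of this assay and not a number. It therefore stands at the limit of > 2000000 nM in this assay, at which 1 of the 3 values shown sits.

Compound 4 `O=c1cc(/C=N\O)c2ccc(OCc3ccccc3)cc2o1` keeps the core of compound 3 and has hydroxy in place of (4-nitrophenyl)amino on a double-bonded nitrogen.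

Going by the values given here, one measured step bears directly on this place: an at least 57-fold higher number from compound 2 to compound 3 (1.76 log units; beyond the scatter). That step is large and beyond the scatter, so a change of group here can move the read-out a long way. Compound 1 also carries hydroxy at this place, on its own core, and gives "not active" (no number reported). This leaves open a result without a number for compound 4.

On the evidence of an at least 57-fold higher number from compound 2 to compound 3 (1.76 log units; beyond the scatter), a large step toward a lower number is expected in this assay, though the direct evidence is thin. The expected step is an at least 13-fold lower number from compound 3 to compound 4 (1.12 log units; beyond the scatter).

For compound 4 the estimated value is 150000 nM, with an expected range from 20000 nM to 1000000 nM.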

Compound 4, half-maximal inhibitory concentration: > 2000000 nM
Compound 4: no number, only a limit; the forecaster's own chance of this, stated with the estimate: 50%; middle value at least 13-fold (1.12 log units) away from the limit.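

In this assay compound 4 gives > 2000000 nM, which is a limit of the assay and not a number. Hydroxy in place of (4-nitrophenyl)amino on a double-bonded nitrogen thus still yields no number, and the step between compound 3 and compound 4 cannot be read, as both entries are limits. Going by these compounds alone, the one readable step is an at least 57-fold higher number from compound 2 to compound 4 (1.76 log units; beyond the scatter), which leaves 2-aminophenyl as the only group at this place on the shared core to give a number so far, while two very different groups now sit at the same limit: the limit of > 2000000 nM in this assay, at which 2 of the 4 values shown sit.

Going by these compounds, how far compound 3 and compound 4 lie past this limit remains unknown, so the two cannot be ordered. Also open, on these data alone, is whether the amino group of 2-aminophenyl matters for the number of compound 2, which a plain phenyl or a 3-aminophenyl at this place would test, and whether a methoxy in place of hydroxy would give any number at all.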